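This account rests on a few compounds, and the source may have more. Where it says the series, first, only, none or still open, it means among the compounds named here.

Measured so far:
compound 1 `O=c1c(C2N=C(c3ccccc3)SS2)coc2cc(Cl)ccc12` — 31% in a functional assay on HEp-2 cells (Homo sapiens) for inhibition, read by sulforhodamine B assay, with a stated time of 48 h, tested at 100 uM; on this read-out lower numbers stand for less inhibition of growth and higher numbers for more inhibition of growth at the one concentration tested
compound 2 `O=c1c(C2N=C(c3ccccc3)SS2)coc2cc(Cl)c(F)cc12` — 52% in this assay

Among the measured compounds shown here, compound 2 stands highest of the two numbers so far; its nearest neighbour is compound 1, and the single step that joins them, a number 21 percentage points higher from compound 1 to compound 2 (beyond the scatter), lies beyond the scatter and is modest in size.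

Compound 3 `O=c1c(C2N=C(c3ccccc3)SS2)coc2cc(Cl)c(Cl)cc12` is not yet measured. It differs from compound 2 by chloro in place of fluoro on an aromatic carbon, on the aromatic carbon ortho to a chloro group, meta to a fused ring and para to a fused ring.

For the measured compounds named here, only one measured step bears on this position, the change from hydrogen to fluoro at the same carbon, which gave the modest rise in a number 21 percentage points higher from compound 1 to compound 2 (beyond the scatter). Going by the values given here, no measured pair shows chloro in place of fluoro anywhere, so the direction of the coming step is uncertain. A step of about the same size as the one already seen, or none beyond the scatter, is expected.

For compound 3 the estimate in this assay is 55%, within 35% to 75%. The estimated change is a number 3 percentage points higher from compound 2 to compound 3 (within the scatter), which is expected to stay within the scatter.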

Compound 3, percent growth inhibition at one concentration: 51%
Compound 3: the middle estimate sits 4 percentage points above what was measured, and the stated range covers the measured number.
By their numbers in this assay, from the lowest: compound 1; then compounds 3 and 2 (each within the scatter of the next).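

In this assay, putting chloro in place of fluoro on the aromatic carbon ortho to a chloro group gives a number 1 percentage points lower from compound 2 to compound 3 (within the scatter) and so does not separate these two groups at this position. Chloro in place of hydrogen on the same carbon gives a number 20 percentage points higher from compound 1 to compound 3 (beyond the scatter) and stands alongside a number 21 percentage points higher from compound 1 to compound 2 (beyond the scatter) as a second step of modest size, so the rise is no longer tied to fluoro alone, and both substituted compounds, compound 2 and compound 3, read above the unsubstituted compound 1. Nothing at hand explains why either group at this carbon goes with the higher read-out.

Still open, as far as these compounds go, is whether a group other than a halogen at this carbon, such as an amine, a methoxy group or a carboxylic acid, would keep the read-out at the level of compound 2 and compound 3 or return it to that of compound 1. Also open, from the compounds shown here alone, is whether a larger halogen such as bromo would extend the same rise, and whether it would survive a change to the phenyl group of the shared core.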